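Replacing the amide's aromatic group with an open chain

The compounds below may be only part of what the source reports. "The series", "measured", "known", "first", "only" and "open" are said of these compounds alone.

Compound 1 `CCn1c(C(=O)Nc2ccc(OC(F)(F)F)cc2)ccc1C(CC)(CC)c1ccc(OCCC(O)(CC)CC)c(C)c1`: > 50000 nM (a limit)
Compound 2 `CCn1c(C(=O)Nc2cccc(C(F)(F)F)c2)ccc1C(CC)(CC)c1ccc(OCCC(O)(CC)CC)c(C)c1`: 23800 nM

Both were tested in a functional assay on PC-3 cells (Homo sapiens) for antiproliferative activity, read by MTT assay, with a stated time of 48 h; on this read-out higher numbers stand for weaker inhibition and lower numbers for stronger inhibition. Among the compounds with values here, compound 2 gives the only actual number, as the other value is a limit. Compound 3 `CCn1c(C(=O)NC(CC(=O)O)C(=O)OC)ccc1C(CC)(CC)c1ccc(OCCC(O)(CC)CC)c(C)c1` differs from compound 2 on the amide-type nitrogen: a group of 9 heavy atoms (5 carbon, 4 oxygen; no ring) in place of a group of 10 heavy atoms (7 carbon, 3 fluorine; one six-membered aromatic ring of carbon only), on an amide-type nitrogen. Within the data shown here, one measured step bears on this place, an at least 2.1-fold lower number from compound 1 to compound 2 (0.32 log units; beyond the scatter), and it is open-ended. That step shows that this nitrogen's group can shift the number, but it exchanged one ring-bearing group for another, so it guides only loosely. A modest rise is expected in this assay, an estimated 2.1-fold higher number from compound 2 to compound 3 (0.32 log units; beyond the scatter). Compound 3 is estimated at 50000 nM, within 20000 nM to 120000 nM.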

Compound 3, half-maximal inhibitory concentration: 11200 nM
The estimate for compound 3 lay 4.5-fold (0.65 log units) above the measured number; the measured number lies below the stated range.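

In this assay, swapping 3-(trifluoromethyl)phenyl for the open chain gives a 2.1-fold lower number from compound 2 to compound 3 (0.33 log units; beyond the scatter), so within these compounds the group on the amide-type nitrogen need not hold an aromatic ring for the number to fall. The open chain also gives an at least 4.4-fold lower number from compound 1 to compound 3 (0.64 log units; beyond the scatter). That step is open-ended, as compound 1 provides only a limit: the limit of > 50000 nM in this assay, at which 1 of the 3 values shown sits.

Which part of the open chain matters remains unresolved. From the compounds shown here alone, whether a plain alkyl chain, or a chain ending in an amine, would lower the number further also stays open.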